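Switching the acid on the aryl ring of the pyrazolone core

The compounds below may be only part of what the source reports. "The series", "measured", "known", "first", "only" and "open" are said of these compounds alone.

Compound 1: `Cc1ccc(-n2[nH]c(C)c(/N=N/c3c(O)cc(S(=O)(=O)O)c4ccccc34)c2=O)cc1C` gives 100%
Compound 2: `Cc1[nH]n(-c2ccc(C(C)(C)C)cc2)c(=O)c1/N=N/c1c(O)cc(S(=O)(=O)O)c2ccccc12` gives 86%
Compound 3: `Cc1[nH]n(-c2ccc(C(=O)O)cc2)c(=O)c1/N=N/c1c(O)cc(S(=O)(=O)O)c2ccccc12` gives < 5%

All three share one core and differ only in the aryl group on the aromatic nitrogen. In an assay on BaF3 cells with thrombopoietin receptor (Homo sapiens) as the target, read by a luciferase reporter (a lower number here means a smaller maximal response, a higher number a larger maximal response), compound 1 sets the top of the series. Compound 2 sits somewhat lower, a number 14 percentage points lower from compound 1 to compound 2 (beyond the scatter). Compound 3 stands apart: its value is a limit of the assay, not a number, as the limit of < 5% in this assay, at which 1 of the 3 values shown sits, records. The two steps leading to it are both large: a number at least 95 percentage points lower from compound 1 to compound 3 (beyond the scatter) and a number at least 81 percentage points lower from compound 2 to compound 3 (beyond the scatter).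

Compound 4, `Cc1[nH]n(-c2cc(S(=O)(=O)O)ccc2Cl)c(=O)c1/N=N/c1c(O)cc(S(=O)(=O)O)c2ccccc12`, has not yet been measured. It carries 2-chloro-5-sulfophenyl in place of 4-carboxyphenyl on an aromatic nitrogen. Going by the values given here, no measured step matches this exact change, so the bearing ones are the two large drops into compound 3, where carboxy arrived on the aromatic ring. Among the compounds with values here, compound 4 keeps an acidic-looking group on that ring, now a sulfo group with a chlorine beside the ring nitrogen link, and nothing among the measured compounds shows such a group restoring the response. Compound 4 is therefore expected to stay near the floor, a number at least 3 percentage points higher from compound 3 to compound 4 (that floor lies within the scatter), with the estimate for compound 4 in this assay being 8%, between 3% and 35%.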

Compound 4, largest response reached (reported as efficacy), in percent of the reference or control that the assay uses: < 5%
Compound 4: no number, only a limit; the forecaster's own chance of this, stated with the estimate: 50%; middle value at least 3 percentage points from the limit.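

In this assay compound 4 records < 5%, which is a limit of the assay and not a number, and compound 3 now sits at that same limit: the limit of < 5% in this assay, at which 2 of the 4 values shown sit.

Against the compounds bearing 3,4-dimethylphenyl and 4-(tert-butyl)phenyl, the swap to 2-chloro-5-sulfophenyl costs nearly the whole response, a number at least 95 percentage points lower from compound 1 to compound 4 (beyond the scatter) and a number at least 81 percentage points lower from compound 2 to compound 4 (beyond the scatter). Among these four compounds, then, the collapse is no longer tied to carboxy alone: both aryl groups carrying carboxy or sulfo end at the limit, both carrying only alkyl groups stay high, no compound goes against this, and the step between compound 3 and compound 4 cannot be read since both values are limits.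

Compound 4 brings in sulfo and chlorine together, so the compounds shown cannot say which of the two goes with the lost response; a plain 2-chlorophenyl group on the same nitrogen would separate them. They also leave open how the response would change with an amine or a methyl ester on the aryl ring in place of the carboxylic acid.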